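The source may hold more compounds than are shown below. What is called first, only, known or untested is meant among the compounds shown, and "the series" means these compounds.

Measured compounds in a functional assay on Huh-7 cells (Homo sapiens) for antiproliferative activity, read by CCK-8 assay, with a stated time of 72 h; on this read-out higher numbers stand for weaker inhibition of growth and lower numbers for stronger inhibition of growth:
- compound 1, `CCC1C(=O)N(C)c2cnc(-n3ccc4cc(C(=O)NC)ccc43)nc2N1c1ccn(C)n1`: 13200 nM
- compound 2, `CC[C@@H]1C(=O)N(C)c2cnc(Nc3ccc(S(=O)(=O)NCC(C)C)cc3)nc2N1C1CCCC1`: 411 nM
- compound 3, `CC[C@@H]1C(=O)N(C)c2cnc(Nc3ccc(S(=O)(=O)NCCCO)cc3)nc2N1C1CCCC1`: 262 nM

Compound 1 gives the highest number of the three; the nearest is compound 2, which sits well beyond the scatter, and compound 3 lies further still. Compound 1 is thus the weakest growth inhibitor of the set by a clear margin.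

The unmeasured compound 4, `CCCNC(=O)c1ccc2c(ccn2-c2ncc3c(n2)N(c2ccn(C)n2)C(CC)C(=O)N3C)c1`, differs from compound 1 in one place: ethyl in place of hydrogen on a saturated chain carbon bound to an amide-type nitrogen. Cut one bond further out, the change reads methylcarbamoyl to propylcarbamoyl.

Going by the values given here, no measured pair repeats this change on the shared core of compound 1. Among the compounds with values here, the only step on record, a 1.6-fold lower number from compound 2 to compound 3 (0.20 log units; within the scatter), alters a chain on a nitrogen of a different kind and on a different part of the molecule, and it stayed within the scatter. It offers no reason to expect the lengthening of the chain in compound 4 to move the number far in either direction.

The expectation for compound 4 is therefore a number close to that of compound 1, with the step of a 1.3-fold lower number from compound 1 to compound 4 (0.12 log units; within the scatter) expected to lie within the scatter. Compound 4 is estimated at 10000 nM, with a range from 4000 nM to 30000 nM.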

Compound 4, concentration for 50% growth inhibition: 7280 nM
Compound 4: middle estimate off by 1.4-fold (0.14 log units), on the high side; measured number inside the range.
By their numbers in this assay, from the lowest: compounds 3 and 2 (each within the scatter of the next); then compounds 4 and 1 (each within the scatter of the next).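

In this assay, the change from methylcarbamoyl to propylcarbamoyl on the shared core of compound 1, with ethyl in place of hydrogen on a saturated chain carbon bound to an amide-type nitrogen, gives a 1.8-fold lower number from compound 1 to compound 4 (0.26 log units; within the scatter), the first step read at this position. This single pair therefore gives no sign that adding ethyl at this place separates the two compounds in this measure of growth inhibition, and the propyl and methyl amides cannot be told apart here. The data on hand offer no explanation for the size of this step.

Open, as far as these compounds go, is whether a longer chain such as hexyl, a branched chain such as isopropyl, or a propyl chain ending in an amine or a carboxylic acid would give a step beyond the scatter at this amide nitrogen. Also open, from the compounds shown here alone, is how the unsubstituted carbamoyl, with hydrogen in place of the methyl of compound 1, would read on the same core, and whether any change at this position could matter on another core.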